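The source may report more compounds than this note shows. Statements on the series, on what has been measured and on what is new or still open speak of the compounds shown alone.

Compound 1 `O=C(CSc1nc(Cc2c(F)cccc2F)cc(=O)[nH]1)c1ccccc1`: > 67000 nM
Compound 2 `Cc1ccc(CSc2nc(Cc3c(F)cccc3F)c(C)c(=O)[nH]2)c(C)c1`: > 65000 nM

Both compounds were tested in an ADME assay on MT4 cells (Homo sapiens) for cytotoxicity, read by MTT assay; a lower number here means that less compound is tolerated, a higher number that more compound is tolerated. Compound 1 gives > 67000 nM, which is a limit of the assay and not a number. Compound 2 gives > 65000 nM, which is also a limit. Compound 2 therefore has no exact place in this assay, and the only other result beside it offers no exact number either. The compound still to be measured, compound 3 `Cc1c(Cc2c(F)cccc2F)nc(SC(C)C)[nH]c1=O`, carries isopropyl in place of 2,4-dimethylbenzyl on a sulfur. For the measured compounds named here, no measured step shows what such a change does in this assay, so a shift no larger than the usual scatter is expected, with no firm direction. The estimated change is a step that the limit leaves unreadable from compound 2 to compound 3. For compound 3 the expected half-maximal cytotoxic concentration is 80000 nM, with an estimated range of 30000 nM to 200000 nM.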

Compound 3, half-maximal cytotoxic concentration: > 77000 nM
Compound 3 was reported as a limit; the forecaster's own chance of this, stated with the estimate: 75%; the middle value does not contradict the limit.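

In this assay compound 3 gives > 77000 nM, which is a limit and not a number. Compound 2 also stands at a limit, so the step between compound 2 and compound 3 cannot be read. The compounds shown leave open what isopropyl in place of 2,4-dimethylbenzyl on a sulfur does to the half-maximal cytotoxic concentration.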